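Switching the aryl substituent on the isoxazole-fused benzoic acid core

The source may hold more compounds than are shown below. What is called first, only, known or untested is meant among the compounds shown, and "the series" means these compounds.

Of the compounds shown here, two have numbers so far. Compound 1 `O=C(O)c1ccc2noc(-c3ccc(NC(=O)c4ccncn4)cc3)c2c1` gives 720 nM in an assay for inhibition of inositol hexakisphosphate kinase 2 (Homo sapiens), read by colorimetric assay, coupled enzyme assay and malachite green, with a stated time of 120 min, in the presence of a further agent that is not named here; on this read-out lower numbers stand for stronger inhibition and higher numbers for weaker inhibition. Compound 2 `O=C(O)c1ccc2noc(-c3cccc(C(F)(F)F)c3)c2c1` gives 1460 nM in this assay, the higher of the two numbers, and its distance from compound 1 lies beyond the usual scatter of the read-out. For the measured compounds named here, no pair of measured compounds differs in only one place, so no single-change step is known.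

Compound 3 `O=C(O)c1ccc2noc(-c3cccc(Oc4ncc(Cl)cc4Cl)c3)c2c1` is the next one to be measured. Relative to compound 2 the change is (3,5-dichloropyridin-2-yl)oxy in place of trifluoromethyl on an aromatic carbon. The shared core and the acid are untouched; only the substituent on the pendant aromatic ring is exchanged, and the entering group is a good deal larger than the leaving one and brings two hydrogen-bond acceptors into that position.

Going by the values given here, with no comparable step to lean on, the expectation is a modest move toward lower numbers, or none beyond the scatter, rather than a large shift in either direction. Compound 3 is therefore estimated at 1000 nM in this assay, with a range of 300 nM to 3500 nM, which corresponds to an expected step of a 1.5-fold lower number from compound 2 to compound 3 (0.16 log units; within the scatter).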

Compound 3, half-maximal inhibitory concentration: 71 nM
Beside the measured number, compound 3's estimate is 14-fold (1.15 log units) above it; measured number below the stated range.
By their numbers in this assay, from the lowest: compound 3; then compound 1; then compound 2.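

In this assay, for the compounds shown here, the exchange of trifluoromethyl for (3,5-dichloropyridin-2-yl)oxy gives a 21-fold lower number from compound 2 to compound 3 (1.31 log units; beyond the scatter) and is the first single-change step. It shows that this place, on an aromatic carbon meta to a large group, tolerates a much larger substituent bearing a six-membered aromatic ring with 1 hetero atom, and that the number falls with this exchange rather than rises; the shared core and the acid are the same on both sides of the step, so the whole move belongs to this one change. Nothing available explains why the step is so large.

This single pair cannot divide the step among the ether oxygen, the ring nitrogen and the two chlorine atoms, and a plain phenoxy group or an unsubstituted pyridin-2-yloxy group at this place would begin to separate them. Also open, on these data alone, is whether an amine or a longer alkyl chain at the same place would give a comparable number, and whether a tetrazole could stand in for the carboxylic acid on the core.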